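Phenyl after cycloheptyl on an aromatic nitrogen

The source may hold more compounds than are shown below. What is called first, only, known or untested is meant among the compounds shown, and "the series" means these compounds.

Measured so far in a physicochemical assay for lipophilicity, at pH 7.4; on this read-out higher numbers stand for higher lipophilicity and lower numbers for lower lipophilicity:
- compound 1 `O=c1[nH]c(Oc2cnn(C3CCCCC3)c2)nc2cnccc12`: 2.2
- compound 2 `O=c1[nH]c(Oc2cnn(C3CCCCCC3)c2)nc2cnccc12`: 2.9

Of the two numbers available, the higher belongs to compound 2 at 2.9, while compound 1 gives 2.2, and the gap between them lies beyond the scatter.

The next compound is compound 3 `O=c1[nH]c(Oc2cnn(-c3ccccc3)c2)nc2cnccc12`, with phenyl in place of cycloheptyl on an aromatic nitrogen.

Within the data shown here, only one measured step bears on this change: a number 0.70 log units higher from compound 1 to compound 2 (beyond the scatter). It is a modest step, with cycloheptyl in place of cyclohexyl on the same kind of nitrogen. Among the measured compounds shown here, no measured step yet has an aromatic ring entering there, so it is only a rough guide. Phenyl is six-membered, as cyclohexyl is, so a fall back towards compound 1 at 2.2 is expected.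

The expected change is a number 0.90 log units lower from compound 2 to compound 3 (beyond the scatter), downward in this assay and beyond the scatter. For compound 3 the estimated value is 2, with an expected range of 1.5 to 2.6.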

Compound 3, distribution coefficient: 1.9
Beside the measured number, compound 3's estimate is 0.10 log units above it; the measured number falls inside the stated range.
By their numbers in this assay, from the lowest: compounds 3 and 1 (each within the scatter of the next); then compound 2.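

In this assay, phenyl on the aromatic nitrogen gives a number 1.00 log units lower from compound 2 to compound 3 (beyond the scatter) and so reverses, in direction and at a somewhat larger size, the gain seen in a number 0.70 log units higher from compound 1 to compound 2 (beyond the scatter). Set against cyclohexyl, the same group gives a number 0.30 log units lower from compound 1 to compound 3 (within the scatter), so at this position the assay does not tell the aromatic six-membered ring from the non-aromatic one, and among the three compounds only the seven-membered ring of compound 2 stands apart. No measurement on hand accounts for either step.

On these data alone, the three groups are all unsubstituted carbocycles, so it remains open whether the agreement between compound 1 and compound 3 would survive a phenyl carrying a fluorine or a methoxy group, or a pyridyl ring in its place. Equally open, as far as these compounds go, is whether the rise at compound 2 follows ring size or carbon count, which a cyclopentyl or a cyclooctyl ring, or an open chain such as n-hexyl, on the same nitrogen could begin to separate.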